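From isopropyl(methyl)amino to diethylamino on a shared core

The source may report more compounds than this note shows. Statements on the series, on what has been measured and on what is new or still open speak of the compounds shown alone.

Among the measured compounds shown here, in a functional assay on the whole organism with Rattus norvegicus as the target (on this read-out higher numbers stand for an effect only at larger amounts of compound and lower numbers for an effect already at smaller amounts), compound 1 (`CCOC(=O)C(=O)Nc1cccc(N)c1C#N`) gives 0.07 mg/kg and compound 2 (`CCOC(=O)C(=O)Nc1cccc(N(C)C(C)C)c1C#N`) gives 1.2 mg/kg as the higher of the two numbers so far. Compound 3 (`CCOC(=O)C(=O)Nc1cccc(N(CC)CC)c1C#N`) has not yet been measured. It carries diethylamino in place of isopropyl(methyl)amino on an aromatic carbon, ortho to a cyano group (diethylamino in place of isopropyl(methyl)amino on an aromatic carbon), and has the same atoms as compound 2, joined differently. For the measured compounds named here, only one measured step bears on this change: a 17-fold higher number from compound 1 to compound 2 (1.23 log units; beyond the scatter) is large and beyond the scatter, but it replaces amino with isopropyl(methyl)amino. Going by the values given here, no measured step exchanges one such substituted amino group for another, so this guide is indirect. With the atoms unchanged, the expected step is no change at the digits printed from compound 2 to compound 3 (within the scatter) and none beyond the scatter is anticipated. Compound 3 is estimated at 1.2 mg/kg in this assay with an expected range from 0.4 mg/kg to 3.6 mg/kg as the likely outcome.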

Compound 3, dose for half-maximal effect: 0.9 mg/kg
Beside the measured number, compound 3's estimate is 1.3-fold (0.12 log units) above it; the range from low to high includes it.
By their numbers in this assay, from the lowest: compound 1; then compounds 3 and 2 (each within the scatter of the next).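

In this assay, moving from isopropyl(methyl)amino to diethylamino on this aromatic carbon, ortho to a cyano group, gives a 1.3-fold lower number from compound 2 to compound 3 (0.12 log units; within the scatter) and so leaves the two arrangements of the same atoms indistinguishable at this position. The earlier large step is therefore not confined to the branched group: a second substituted amino group, free of branching, also stands well apart from the unsubstituted amino group, with a 13-fold higher number from compound 1 to compound 3 (1.11 log units; beyond the scatter) as the result. Nothing measured here accounts for either step.

From the compounds shown here alone, it remains open whether a smaller group such as methylamino or dimethylamino, or a ring amine such as pyrrolidine, would fall with compound 1 or with compounds 2 and 3. Going by these compounds, it is also open whether the same separation would persist if a carboxylic acid took the place of the ethyl ester.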